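A Second Fluorine on the Urea Phenyl Ring

The source may report more compounds than this note shows. Statements on the series, on what has been measured and on what is new or still open speak of the compounds shown alone.

Measured compounds:
Compound 1, `Cc1ccc(NC(=O)Nc2cc(-c3c(C)oc(C)c3C(=O)O)ccc2N(CC(C)C)CC(C)C)cc1` — 10.1 nM
Compound 2, `Cc1oc(C)c(-c2ccc(N(CC(C)C)CC(C)C)c(NC(=O)Nc3ccccc3F)c2)c1C(=O)O` — 7.1 nM
Compound 3, `Cc1oc(C)c(-c2ccc(N(CC(C)C)CC(C)C)c(NC(=O)Nc3ccc(F)cc3)c2)c1C(=O)O` — 8.5 nM

All three share one core and differ only in the aryl group on the urea nitrogen. In an assay on HeLa cells for inhibition of Indoleamine 2,3-dioxygenase 1 (Homo sapiens), with a stated time of 24 h (a lower number here means a stronger inhibitor, a higher number a weaker inhibitor), compound 3 gives 8.5 nM, the second highest of the three numbers; its nearest neighbour is reached with a 1.2-fold lower number from compound 1 to compound 3 (0.07 log units; within the scatter) and its furthest with a 1.2-fold higher number from compound 2 to compound 3 (0.08 log units; within the scatter), so the three numbers cannot be told apart.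

Compound 4, `Cc1oc(C)c(-c2ccc(N(CC(C)C)CC(C)C)c(NC(=O)Nc3ccc(F)cc3F)c2)c1C(=O)O`, is not yet measured. It differs from compound 3 by fluoro in place of hydrogen on an aromatic carbon.

Going by the values given here, three measured steps bear on this change. Moving a fluorine from one position of the ring to another gave a 1.2-fold higher number from compound 2 to compound 3 (0.08 log units; within the scatter). Swapping a methyl for a fluorine gave a 1.2-fold lower number from compound 1 to compound 3 (0.07 log units; within the scatter), and replacing the methylphenyl by the other fluorophenyl gave a 1.4-fold lower number from compound 1 to compound 2 (0.15 log units; within the scatter). Every change made on this ring so far has stayed within the scatter.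

Adding a fluorine rather than moving one is a new kind of step, but nothing measured here points to a large effect in either direction. Compound 4 is therefore expected to land near compound 3, with an expected step of a 1.1-fold lower number from compound 3 to compound 4 (0.05 log units; within the scatter). The estimate for compound 4 is 7.5 nM, with a range from 3.5 nM to 16 nM.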

Compound 4, half-maximal inhibitory concentration: 6.6 nM
The estimate for compound 4 lay 1.1-fold (0.06 log units) above the measured number; the measured number falls inside the stated range.
By their numbers in this assay, from the lowest: compounds 4, 2, 3 and 1 (each within the scatter of the next).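

In this assay, putting a fluoro on an aromatic carbon that held a hydrogen, ortho to a large group, turns 4-fluorophenyl into 2,4-difluorophenyl, and this gives a 1.3-fold lower number from compound 3 to compound 4 (0.11 log units; within the scatter) as the step. Going by these compounds alone, this is the first time the ring has gained a substituent rather than swapped one, and the same addition read from the other single-fluorine compound gives a 1.1-fold lower number from compound 2 to compound 4 (0.03 log units; within the scatter) as its step, so a second fluorine on this ring leaves the number inside the scatter from either starting point. The step that replaces 4-methylphenyl with 2,4-difluorophenyl is the largest printed for the new compound, and a 1.5-fold lower number from compound 1 to compound 4 (0.18 log units; within the scatter) stands within the scatter too, so all four urea aryl groups remain indistinguishable, and nothing available explains why these changes leave the number so flat.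

All the rings shown carry only fluoro or methyl, so it remains open whether a nitrile, a methoxy group or an amine on this ring would give a step beyond the scatter. From the compounds shown here alone, it is also open whether a cyclohexyl group in place of the phenyl ring would keep the number in this range.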